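The compounds below may be only part of what the source reports. "The series", "measured", "known", "first", "only" and "open" are said of these compounds alone.

In a functional assay on HeLa cells (Homo sapiens) for antiproliferative activity, read by CCK-8 assay, with a stated time of 48 h (on this read-out lower numbers stand for stronger inhibition and higher numbers for weaker inhibition), compound 1 (`COc1ccc(/C=C\c2cc(OC)c(OC)c(OC)c2)cc1OCc1ccc(CN2CCCCC2C(=O)O)cc1`) gives 14200 nM and compound 2 (`COc1ccc(/C=C\c2cc(OC)c(OC)c(OC)c2)cc1OCc1ccc(CO)cc1`) gives 7600 nM, so compound 2 stands within the scatter of compound 1. Compound 3 (`COc1ccc(/C=C\c2cc(OC)c(OC)c(OC)c2)cc1OCc1ccc(CNCCN(C)C)cc1`) differs from compound 2 by (2-(dimethylamino)ethyl)amino in place of hydroxy on a saturated chain carbon bound to an aromatic carbon, with (2-(dimethylamino)ethyl)amino in place of hydroxy on a saturated chain carbon bound to an aromatic carbon. For the measured compounds named here, the only measured step on that carbon, a 1.9-fold lower number from compound 1 to compound 2 (0.27 log units; within the scatter), stayed within the scatter, so no step beyond the scatter is expected in this assay. The expected step is a 1.3-fold lower number from compound 2 to compound 3 (0.10 log units; within the scatter). Compound 3 is estimated at 6000 nM, with an expected range from 1800 nM to 20000 nM.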

Compound 3, half-maximal inhibitory concentration: 9400 nM
Beside the measured number, compound 3's estimate is 1.6-fold (0.19 log units) below it; low and high end bracket the measured number.
By their numbers in this assay, from the lowest: compounds 2, 3 and 1 (each within the scatter of the next).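

In this assay, (2-(dimethylamino)ethyl)amino in place of hydroxy on a saturated chain carbon bound to an aromatic carbon gives a 1.2-fold higher number from compound 2 to compound 3 (0.09 log units; within the scatter), and in place of 2-carboxypiperidin-1-yl it gives a 1.5-fold lower number from compound 1 to compound 3 (0.18 log units; within the scatter). All three groups on this carbon thus stand within the scatter of one another, so the open amine chain adds no step beyond the scatter to those the earlier pair showed. No evidence on the cause accompanies this result. As far as these compounds go, whether a primary amine, a morpholine ring or a longer chain on this carbon would move the number beyond the scatter stays open.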